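The source may report more compounds than this note shows. Statements on the series, on what has been measured and on what is new or still open speak of the compounds shown alone.

Working notes on the series, cytotoxicity arm.

Compound 1 `CCCCCCNc1cnc(C(=O)NCc2ccccc2)cn1` is tested in an ADME assay on HEL cells (Homo sapiens) for cytotoxicity, read by microscopy, with a stated time of 6 days; a lower number here means that less compound is tolerated, a higher number that more compound is tolerated. Its read-out in this assay is a limit of the assay and not a number: compound 1 gives > 100000 nM. Compound 2 `CCCCNc1cnc(C(=O)NCc2ccccc2)cn1` differs from compound 1 by hydrogen in place of ethyl on a saturated chain carbon, four bonds along the chain from a nitrogen on an aromatic ring. In this assay compound 2 also sits at a limit, giving > 100000 nM. The step that the two limits leave unreadable from compound 1 to compound 2 is therefore not readable as a size; both values are limits of the assay.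

Compound 3 `CCCCCCCNc1cncc(C(=O)NCc2ccccc2)n1` has a core that differs from the core of compound 1; the difference between the two cores is not broken down here. In this assay compound 3 likewise reaches only a limit, > 100000 nM. All three values shown sit at the limit of > 100000 nM in this assay, at which 3 of the 3 values shown sit.

Compound 4 `CCCCCNc1cncc(C(=O)NCc2ccccc2)n1` is not yet measured. It differs from compound 3 by hydrogen in place of ethyl on a saturated chain carbon, five bonds along the chain from a nitrogen on an aromatic ring. Within the data shown here, this is the same kind of change as the one from compound 1 to compound 2, not the same change: in the earlier pair the place is four bonds along the chain from a nitrogen on an aromatic ring, here it is five bonds along the chain from a nitrogen on an aromatic ring.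

The step from compound 3 to compound 4 in this assay is expected to be a number no higher from compound 3 to compound 4 (the limit leaves the size open), resting on compound 3 giving > 100000 nM and on (the limit of > 100000 nM in this assay, at which 3 of the 3 values shown sit), where every value shown sits. For compound 4 the expected read-out in this assay is 100000 nM, with a range from 50000 nM to 300000 nM, and most likely again only a limit.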

Compound 4, minimum cytotoxic concentration: > 100000 nM
Compound 4 was reported as a limit; the forecaster's own chance of this, stated with the estimate: 85%; the middle value sits exactly at the limit.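

Compound 3 and compound 4 both give only a limit of the assay in this assay, so no step between them can be read as a size: the limit of > 100000 nM in this assay, at which 4 of the 4 values shown sit.

The compounds shown leave open what concentration in this assay would first prove cytotoxic for any of compound 1, compound 2, compound 3 or compound 4, and whether hydrogen in place of ethyl on the chain changes that concentration at all.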